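A few compounds are considered here, and "the series" means these few. Any claim that something is new, unique, unknown or untested is made for them only; others in the source may bear on it.

Of the compounds shown here, three have been read in an ADME assay on MT4 cells (Homo sapiens) for cytotoxicity, read by MTT assay, with a stated time of 5 days; on this read-out higher numbers stand for lower toxicity in this test and lower numbers for higher toxicity in this test. Among the measured compounds shown here, compound 1 `Cc1cccc(C)c1Oc1cc(Nc2ccc(C#N)cc2)[nH]c(=O)c1Br` gives 63000 nM, the only exact number among them. Compound 2 `Cc1cc(C#N)cc(C)c1Oc1cc(Nc2ccc(C#N)cc2)[nH]c(=O)c1Cl` gives > 319000 nM, which is a limit and not a number. Compound 3 `COc1cc(Oc2c(C)cc(C#N)cc2C)cc(Nc2ccc(C#N)cc2)n1` gives > 147000 nM, which is also a limit. Compound 2 therefore has no exact place on the scale, and its limit is the higher of the two seen so far.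

Compound 4 `Cc1cccc(C)c1Oc1cc(Nc2ccc(C#N)cc2)[nH]c(=O)c1Cl` has not yet been measured. It departs from compound 2 by a single change, hydrogen in place of cyano on an aromatic carbon, meta to two methyl groups and para to a large group: hydrogen in place of cyano on an aromatic carbon. For the measured compounds named here, no measured pair shows this change on its own, so its size in this assay can only be expected. The best guide is compound 1, which also lacks the cyano group and gives 63000 nM. A step well beyond the usual scatter is therefore expected, towards lower numbers and so higher toxicity in this test, estimated as an at least 4.5-fold lower number from compound 2 to compound 4 (0.65 log units; beyond the scatter). For compound 4 the expected value is 70000 nM. The estimated range for compound 4 runs from 25000 nM to 200000 nM.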

Compound 4, half-maximal cytotoxic concentration: 29000 nM
The estimate for compound 4 lay 2.4-fold (0.38 log units) above the measured number; the range from low to high includes it.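

In this assay, among the compounds shown here, hydrogen in place of cyano on the aromatic carbon, meta to two methyl groups and para to a large group, gives an at least 11-fold lower number from compound 2 to compound 4 (1.04 log units; beyond the scatter), the first reading of this change on its own, and a large one that shows the cyano group counts for much at this place on the shared core. The true size of that step cannot be fixed, as compound 2 stands only as a limit and not as a number: the limit of > 319000 nM in this assay, at which 1 of the 4 values shown sits. Chloro in place of bromo on an aromatic carbon now also has a reading, a 2.2-fold lower number from compound 1 to compound 4 (0.34 log units; beyond the scatter), which is modest, so in this small set the exchange of one halogen for the other moves the number less than the loss of the cyano group does.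

Going by these compounds, it remains open whether the cyano step would carry over with bromo in place of chloro, and how far above the limit the true number of compound 2 lies. Also open is what an amine or a carboxylic acid on that same aromatic carbon would do to the number, and the compounds shown give no reason for either step.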